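The compounds below may be only part of what the source reports. "The series", "measured", "known", "first", "only" and "open" are said of these compounds alone.

Measured so far in an assay on isolated protein for inhibition of aldehyde dehydrogenase 1A1 (Homo sapiens), read by spectrophotometry, tested at 10 uM; on this read-out lower numbers stand for less inhibition and higher numbers for more inhibition at the one concentration tested (going by the name of the read-out):

compound 1 `Cc1cccc(Cn2c(CN3CCN(C(=O)c4ccc(C(F)(F)F)cc4)CC3)nc3ccccc32)c1` — 22.9%
compound 2 `Cc1cccc(Cn2c(CN3CCN(C(=O)c4ccc(Br)cc4)CC3)nc3ccccc32)c1` — 25.8%
compound 3 `Cc1cccc(Cn2c(CN3CCN(C(=O)c4cccnc4)CC3)nc3ccccc32)c1` — 24.5%

Compound 3 stands second highest of the three numbers, but the gaps to its neighbours are small: a number 1.3 percentage points lower from compound 2 to compound 3 (within the scatter) and a number 1.6 percentage points higher from compound 1 to compound 3 (within the scatter) both fall within the scatter, so the three measured compounds read as one level in this assay.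

Compound 4 `Cc1ccc(C(=O)N2CCN(Cc3nc4ccccc4n3Cc3cccc(C)c3)CC2)cc1` is the next member. Against compound 3 the change is 4-methylphenyl in place of pyridin-3-yl on a carbonyl carbon

Going by the values given here, the steps that bear on this are the two earlier swaps of the aryl group on the carbonyl carbon, a number 1.6 percentage points higher from compound 1 to compound 3 (within the scatter) and a number 1.3 percentage points lower from compound 2 to compound 3 (within the scatter), together with the ring-substituent swap a number 2.9 percentage points higher from compound 1 to compound 2 (within the scatter). None of them moved the number beyond the scatter, so varying the aryl on the carbonyl carbon has so far left the inhibition unchanged on this read-out. On that basis a step of about a number 0.5 percentage points lower from compound 3 to compound 4 (within the scatter) is expected, i.e. nothing beyond the scatter. Compound 4 is therefore estimated at 24%, with a range from 14% to 34%.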

Compound 4, a percentage reported as inhibition, at one concentration (the size of the read-out at that concentration, not a potency): 64.9%
For compound 4 the middle estimate is 40.9 percentage points below the measured one, outside the stated range (above it).
By their numbers in this assay, from the lowest: compounds 1, 3 and 2 (each within the scatter of the next); then compound 4.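

In this assay the aryl group on the carbonyl carbon now proves able to move the number: 4-methylphenyl in place of pyridin-3-yl gives a number 40.4 percentage points higher from compound 3 to compound 4 (beyond the scatter) in this series. The para-substituent swaps point the same way, with methyl in place of bromo giving a number 39.1 percentage points higher from compound 2 to compound 4 (beyond the scatter) and methyl in place of trifluoromethyl giving a number 42 percentage points higher from compound 1 to compound 4 (beyond the scatter) on the same aromatic carbon, so the outcome depends on which group is present, and compounds 1, 2 and 3 show no such rise. Nothing at hand explains this rise.

As far as these compounds go, it remains open whether the rise is specific to methyl, or whether ethyl, methoxy or chloro in place of the methyl of 4-methylphenyl would hold it. A reading at one concentration also leaves the potency of compound 4 open.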